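The source may hold more compounds than are shown below. What is called first, only, known or untested is meant among the compounds shown, and "the series" means these compounds.

Compound 1 `CNC(=O)c1cccc(S(=O)(=O)c2ccccc2Cc2c3c(n(CC(=O)O)c2C)CCNC3=O)c1` gives 240 nM in a functional assay on CHO.K1 cells for antagonist activity at prostaglandin D2 receptor 2 (Homo sapiens), read by GTPgammaS binding, with a stated time of 1 h; on this read-out lower numbers stand for stronger inhibition and higher numbers for weaker inhibition. Compound 2 `COc1ccc(S(=O)(=O)c2ccccc2Cc2c3c(n(CC(=O)O)c2C)CCNC3=O)cc1` gives 3.9 nM. Compound 3 `Cc1c(Cc2ccccc2S(=O)(=O)N(C)Cc2ccccc2)c2c(n1CC(=O)O)CCNC2=O` gives 26 nM.

Among these three, compound 2 stands lowest in this assay, and both of its gaps to the others lie beyond the scatter: a 62-fold lower number from compound 1 to compound 2 (1.79 log units; beyond the scatter) and a 6.7-fold higher number from compound 2 to compound 3 (0.82 log units; beyond the scatter). The remaining step, a 9.2-fold lower number from compound 1 to compound 3 (0.97 log units; beyond the scatter), also changed only the group on the sulfonyl sulfur. So every measured step shows that what sits on the sulfonyl sulfur moves the number a great deal, while the sulfonyl itself stayed in place throughout.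

Compound 4 `Cc1c(Cc2ccccc2Oc2ccccc2)c2c(n1CC(=O)O)CCNC2=O` takes the change further: phenoxy in place of (4-methoxyphenyl)sulfonyl on an aromatic carbon. Among the measured compounds shown here, no measured step removes the sulfonyl, so the three steps bear on this change only loosely, through the sensitivity they reveal at this side of the core. Taking the best of the series apart at that point is expected to cost potency, so a higher number is expected for compound 4, a 15-fold higher number from compound 2 to compound 4 (1.19 log units; beyond the scatter). Compound 4 is therefore estimated at 60 nM, within a range from 10 nM to 400 nM.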

Compound 4, half-maximal inhibitory concentration: 530 nM
Estimate against measurement, compound 4: 8.8-fold (0.95 log units) below, and the stated range ends below it.
By their numbers in this assay, from the lowest: compound 2; then compound 3; then compound 1; then compound 4.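

In this assay, among the compounds shown here, this is the first step at this position that removes the sulfonyl rather than only changing what sits on it, and it is large: a 140-fold higher number from compound 2 to compound 4 (2.13 log units; beyond the scatter). The earlier steps shown here showed that the group on the sulfur matters, whereas this one shows that keeping an aromatic ring at this place does not preserve the potency of compound 2 once the sulfonyl link gives way to an oxygen. The step also removes the methoxy, so two features change together and their shares of the loss cannot be separated. No measurement here explains why the number rises so much.

Still open is which of the two changes accounts for the loss. A 4-methoxyphenoxy group, or a phenylsulfonyl group, at the same place would separate the contribution of the methoxy from that of the sulfonyl.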